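Aryl-triazole series: a toluene substituent on the triazole nitrogen

The source may report more compounds than this note shows. Statements on the series, on what has been measured and on what is new or still open speak of the compounds shown alone.

Measured so far in a functional assay on HCT-116 cells (Homo sapiens) for antiproliferative activity, read by MTT assay, with a stated time of 48 h; a lower number here means a stronger inhibitor, a higher number a weaker inhibitor:
- compound 1 `COc1cc(/C=C/C(C)=O)ccc1OCc1cn(-c2c(F)cccc2F)nn1`: 37700 nM
- compound 2 `COc1cc(/C=C/C(C)=O)ccc1OCc1cn(-c2ccc(/N=N/c3ccccc3)cc2)nn1`: > 100000 nM
- compound 3 `COc1cc(/C=C/C(C)=O)ccc1OCc1cn(-c2ccc([N+](=O)[O-])cc2)nn1`: 96300 nM

The value of compound 2 is a limit of this assay, not a number (the limit of > 100000 nM in this assay, at which 1 of the 3 values shown sits). Among the two numbers, compound 1 stands lowest; its nearest neighbour is compound 3, and a 2.6-fold higher number from compound 1 to compound 3 (0.41 log units; beyond the scatter). The other measured step, an at least 1.0-fold lower number from compound 2 to compound 3 (0.01 log units; that floor lies within the scatter), lies within the scatter and says nothing about the group on the aromatic nitrogen beyond that.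

Compound 4 `COc1cc(/C=C/C(C)=O)ccc1OCc1cn(-c2ccc(C)cc2)nn1` is not yet measured. It differs from compound 1 at that same position: 4-methylphenyl in place of 2,6-difluorophenyl on an aromatic nitrogen. Within the data shown here, the only measured step that bears on this change is the one from compound 1 to compound 3, where the 2,6-difluorophenyl also left and a substituted phenyl entered, giving a modest rise. With 4-methylphenyl entering instead, a rise of similar or smaller size is expected, or none beyond the scatter; a move past the limit is not expected. Compound 4 is therefore estimated at 55000 nM in this assay, between 25000 nM and 100000 nM, which means an expected 1.5-fold higher number from compound 1 to compound 4 (0.16 log units; within the scatter).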

Compound 4, half-maximal inhibitory concentration: 76600 nM
Beside the measured number, compound 4's estimate is 1.4-fold (0.14 log units) below it; measured number inside the range.
By their numbers in this assay, from the lowest: compound 1; then compounds 4 and 3 (each within the scatter of the next). At a limit, above all of these: compound 2.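

In this assay the change from 2,6-difluorophenyl to 4-methylphenyl gives a 2.0-fold higher number from compound 1 to compound 4 (0.31 log units; beyond the scatter) and so a second replacement of the 2,6-difluorophenyl, this time by a group without nitrogen or oxygen, also leaves compound 1 with the lower number. The change from 4-nitrophenyl to 4-methylphenyl gives a 1.3-fold lower number from compound 3 to compound 4 (0.10 log units; within the scatter) and so this assay does not separate 4-methylphenyl from 4-nitrophenyl on the aromatic nitrogen, and the change from compound 1 reads much the same with either group. The remaining step gives an at least 1.3-fold lower number from compound 2 to compound 4 (0.11 log units; that floor lies within the scatter) and so it sets no order between these two compounds. The value of compound 2 remains a limit and not a number: the limit of > 100000 nM in this assay, at which 1 of the 4 values shown sits.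

From the compounds shown here alone, it remains open whether the lower number of compound 1 follows the fluorine atoms themselves or where they sit; a 4-fluorophenyl or an unsubstituted phenyl would separate the two. Going by these compounds, the effect of an amine or a carboxylic acid on this phenyl ring is also open.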